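Methoxymethyl to methyl in a weakly active series

The source may report more compounds than this note shows. Statements on the series, on what has been measured and on what is new or still open speak of the compounds shown alone.

Among the measured compounds shown here, the series so far sits at the weak end of a functional assay for inhibition, with Homo sapiens as the target; on this read-out higher numbers stand for weaker inhibition and lower numbers for stronger inhibition. Compound 1 `CCCc1nc(C)n2c(O)nncc12` reaches only the limit of the assay, > 48000 nM, which is a limit and not a number. Compound 2 `CCCc1nc(Br)c2c(Br)nnc(O)n12` gives 48000 nM. Compound 3 `COCc1ncc2cnnc(S)n12` likewise stops at the limit, > 48000 nM, a limit rather than a measured number. Two of the three values shown sit at this limit (the limit of > 48000 nM in this assay, at which 2 of the 3 values shown sit). Compound 4 `Cc1ncc2cnnc(S)n12` differs from compound 3 by hydrogen in place of methoxy on a saturated chain carbon bound to an aromatic carbon. For the measured compounds named here, no step between measured compounds is available to size this change. Compound 4 is expected to remain near the limit, with a step of a number no higher from compound 3 to compound 4 (the limit leaves the size open) expected to amount to nothing beyond the scatter. Compound 4 is estimated at 48000 nM, between 20000 nM and 200000 nM.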

Compound 4, half-maximal inhibitory concentration: > 48000 nM
Compound 4 ended at the assay's limit; the forecaster's own chance of this, stated with the estimate: 75%; the middle value sits exactly at the limit.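

No step can be read from compound 3 to compound 4 because both values are limits: the limit of > 48000 nM in this assay, at which 3 of the 4 values shown sit.

The compounds shown leave open whether methoxymethyl to methyl changes inhibition at all.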